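Halogen additions to the phenyl of compound 1

The source may hold more compounds than are shown below. What is called first, only, known or untested is meant among the compounds shown, and "the series" means these compounds.

Compound 1 `O=S(=O)(/C=C/c1ccccc1)Cc1ccc(Nc2ncnc3ccccc23)cc1` is the starting point. In a functional assay on HT-29 cells (Homo sapiens) (on this read-out lower numbers stand for stronger inhibition of growth and higher numbers for weaker inhibition of growth), compound 1 gives > 100000 nM, which is a limit of the assay and not a number (the limit of > 100000 nM in this assay, at which 1 of the 2 values shown sits). Compound 2 `O=S(=O)(/C=C/c1ccc(F)cc1)Cc1ccc(Nc2ncnc3ccccc23)cc1` in this assay gives 1000 nM. The measured step is an at least 100-fold lower number from compound 1 to compound 2 (2.00 log units; beyond the scatter). Compound 3 `O=S(=O)(/C=C/c1ccc(F)cc1Cl)Cc1ccc(Nc2ncnc3ccccc23)cc1` differs from compound 1 by 2-chloro-4-fluorophenyl in place of phenyl on a double-bonded chain carbon bound to a double-bonded chain carbon. The fluoro step bears on this change and points in the same direction, so a large drop beyond the scatter is expected. For compound 3 a value of 700 nM is estimated, within 200 nM to 3000 nM. This expectation corresponds to an at least 140-fold lower number from compound 1 to compound 3 (2.15 log units; beyond the scatter).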

Compound 3, concentration for 50% growth inhibition: 100000 nM
Compound 3: middle estimate off by 140-fold (2.15 log units), on the low side, and the stated range ends below it.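

Within 2-chloro-4-fluorophenyl, the added chloro does not add to the fluoro step but runs against it, with a 100-fold higher number from compound 2 to compound 3 (2.00 log units; beyond the scatter) in this assay. Halogen changes on this phenyl therefore do not all move the number in the same direction. The whole change on the phenyl gives a number no higher from compound 1 to compound 3 (the limit leaves the size open). The size of this step cannot be read. The value of compound 1 is a limit and not a number: the limit of > 100000 nM in this assay, at which 1 of the 3 values shown sits.

Open, going by these compounds, is whether chloro alone on the phenyl of compound 1 behaves as it does in compound 3. Also open, on these data alone, is how a methoxy group or an amine on this phenyl would read.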